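The source may report more compounds than this note shows. Statements on the series, on what has been measured and on what is new or still open speak of the compounds shown alone.

Measured in a functional assay on the whole organism with Mus musculus as the target; on this read-out higher numbers stand for an effect only at larger amounts of compound and lower numbers for an effect already at smaller amounts:

Compound 1 `Cn1nc(-c2cccc(C(F)(F)F)c2)n(C)c1=S`: > 50 mg/kg (a limit)
Compound 2 `Cn1nc(-c2ccc(F)cc2)n(C)c1=S`: 0.61 mg/kg
Compound 3 `Cn1nc(-c2ccccc2F)n(C)c1=S`: 0.74 mg/kg

Compound 3 gives 0.74 mg/kg and compound 2 gives 0.61 mg/kg, and these two numbers lie within the usual scatter of each other, so they cannot be told apart. Both compounds carry fluoro, placed differently.

Compound 1, which carries trifluoromethyl, gives > 50 mg/kg, and this is a limit of the assay and not a number.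

The next compound to be tested is compound 4 `Cn1nc(-c2ccccc2)n(C)c1=S`, which differs from compound 3 in one place: hydrogen in place of fluoro on an aromatic carbon. In words, this is hydrogen in place of fluoro on an aromatic carbon.

Among the measured compounds shown here, no measured pair shows this exchange on its own, so any expectation is loose. Starting from compound 3 at 0.74 mg/kg, a modest step is expected in this assay, more likely toward a somewhat higher number, and possibly none beyond the scatter. The expected change is a 1.4-fold higher number from compound 3 to compound 4 (0.13 log units; within the scatter). For compound 4 the estimated value is 1 mg/kg, with an expected range from 0.4 mg/kg to 3 mg/kg.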

Compound 4, dose for half-maximal effect: 0.15 mg/kg
Beside the measured number, compound 4's estimate is 6.7-fold (0.82 log units) above it; measured number below the stated range.
By their numbers in this assay, from the lowest: compound 4; then compounds 2 and 3 (each within the scatter of the next). At a limit, above all of these: compound 1.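

Among the compounds shown here, compound 4 gives the first direct reading of fluoro against hydrogen in this assay: on the aromatic carbon ortho to a group of 8 heavy atoms, the exchange brings a 4.9-fold lower number from compound 3 to compound 4 (0.69 log units; beyond the scatter), and the other fluoro placement points the same way, with a 4.1-fold lower number from compound 2 to compound 4 (0.61 log units; beyond the scatter). Hydrogen in place of trifluoromethyl runs in that direction too, and by much more, with an at least 330-fold lower number from compound 1 to compound 4 (2.52 log units; beyond the scatter). The reading for compound 1 is a limit and not a number, so the true size of that step stays unknown: the limit of > 50 mg/kg in this assay, at which 1 of the 4 values shown sits.

As far as these compounds go, in these three pairs, every group exchanged for hydrogen goes with a higher number, but all three groups contain fluorine, so it remains open whether a chloro, methoxy or amine group on the same ring would follow that direction. Also open, from the compounds shown here alone, is how the shared core responds to changes elsewhere, for example an ethyl group in place of either methyl group on its nitrogens.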